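This account rests on a few compounds, and the source may have more. Where it says the series, first, only, none or still open, it means among the compounds named here.

Measured in a functional assay on the whole organism for inhibition, with Cavia porcellus as the target; a higher number here means that more compound is needed for the effect, a lower number that less compound is needed:

- Compound 1 `COc1ccccc1OCC1SCCN1C(=O)CC(C)=O`: 30 mg/kg
- Compound 2 `CCCC(=O)CC(=O)N1CCSC1COc1ccccc1OC`: 42 mg/kg
- Compound 3 `CNC(=O)CC(=O)N1CCSC1COc1ccccc1OC`: 21 mg/kg

Compound 3, at 21 mg/kg, cannot be separated from the other two compounds, since both of its measured steps lie within the scatter. These are a 1.4-fold lower number from compound 1 to compound 3 (0.15 log units; within the scatter) and a 2.0-fold lower number from compound 2 to compound 3 (0.30 log units; within the scatter).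

Compound 4 `COc1ccccc1OCC1SCCN1C(=O)CC(=O)NCc1ccccn1` differs from compound 3 in one place: pyridin-2-yl in place of hydrogen on a saturated chain carbon bound to an amide-type nitrogen. Here pyridin-2-yl stands in place of hydrogen on a saturated chain carbon bound to an amide-type nitrogen, turning methylamino into ((pyridin-2-yl)methyl)amino.

The two steps above bear most closely on this change, as each exchanges a group on the same carbonyl carbon. The remaining step, a 1.4-fold higher number from compound 1 to compound 2 (0.15 log units; within the scatter), also stays within the scatter. Across these three compounds, then, the changes have not moved the number measurably. However, no measured step introduces pyridin-2-yl, so this evidence is indirect and the range is kept wide. No shift beyond the scatter is expected in this assay, and no direction is favoured.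

The estimated change is a 1.1-fold lower number from compound 3 to compound 4 (0.02 log units; within the scatter), which is expected to lie within the scatter. For compound 4 the expected value is 20 mg/kg. The estimated range for compound 4 runs from 8 mg/kg to 50 mg/kg.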

Compound 4, dose for half-maximal effect: 26 mg/kg
Estimate against measurement, compound 4: 1.3-fold (0.11 log units) below, and the stated range covers the measured number.
By their numbers in this assay, from the lowest: compounds 3, 4, 1 and 2 (each within the scatter of the next).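

In this assay, among the compounds shown here, the step that sets pyridin-2-yl in place of hydrogen on a saturated chain carbon bound to an amide-type nitrogen gives a 1.2-fold higher number from compound 3 to compound 4 (0.09 log units; within the scatter) and so shows that this position can carry an aromatic ring without a measurable shift, which the smaller groups of the earlier compounds could not show. The wider comparisons agree, with a 1.6-fold lower number from compound 2 to compound 4 (0.21 log units; within the scatter) and a 1.2-fold lower number from compound 1 to compound 4 (0.06 log units; within the scatter) leaving ((pyridin-2-yl)methyl)amino on the carbonyl carbon inseparable from both propyl and methyl in that place, so that all four compounds now stand within the scatter of their neighbours and no change at this carbonyl carbon has yet moved the number measurably. Nothing further is available here to explain this flat result.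

Whether phenyl in place of pyridin-2-yl would read the same remains open, so the compounds shown cannot tell what the ring nitrogen contributes. As far as these compounds go, it is also open whether a carboxylic acid, a dimethylamino group or a longer chain on the same saturated chain carbon would bring the first shift beyond the scatter, in either direction.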